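This account rests on a few compounds, and the source may have more. Where it says the series, first, only, none or still open, it means among the compounds named here.

Measured compounds in an assay on microsomes from intestine for inhibition of acyl-CoA:cholesterol acyltransferase (Oryctolagus cuniculus); on this read-out lower numbers stand for stronger inhibition and higher numbers for weaker inhibition:
Compound 1 `CC(C)c1cccc(C(C)C)c1OC(=O)NC(=O)SCCc1ccccc1` gives 880 nM.
Compound 2 `CC(C)c1cccc(C(C)C)c1OC(=O)NC(=O)SCCCc1ccccc1` gives 69 nM.
Compound 3 `CC(C)c1cccc(C(C)C)c1OC(=O)NC(=O)SC1CCCCC1` gives 97 nM.

Compound 2 has the smallest of the three numbers in this assay, but compound 3 is only a 1.4-fold higher number from compound 2 to compound 3 (0.15 log units; within the scatter) away, a gap within the scatter, so the two cannot be told apart. Compound 1 stands well apart from both.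

Compound 4 `CCCCCCCCCCCSC(=O)NC(=O)Oc1c(C(C)C)cccc1C(C)C` differs from compound 2 by octyl in place of phenyl on a saturated chain carbon, three bonds along the chain from a sulfur, so the sulfur now carries a long unbranched chain and no ring. Going by the values given here, two measured steps bear on this. The step of a 13-fold lower number from compound 1 to compound 2 (1.11 log units; beyond the scatter) shows that making the chain on the sulfur one carbon longer produced a large drop in the number. The step of a 1.4-fold higher number from compound 2 to compound 3 (0.15 log units; within the scatter) shows that the phenyl ring can be swapped for a saturated ring without a change beyond the scatter, so the ring itself seems not to be what matters. Among the compounds with values here, neither step covers a chain as long as the one in compound 4, so the comparison is indirect.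

On that basis a small step in this assay is expected, a 1.7-fold lower number from compound 2 to compound 4 (0.24 log units; within the scatter). Compound 4 is estimated at 40 nM, with a range from 10 nM to 200 nM.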

Compound 4, half-maximal inhibitory concentration: 210 nM
Compound 4: the middle estimate sits 5.3-fold (0.72 log units) below what was measured; measured number outside the range, above it.
By their numbers in this assay, from the lowest: compounds 2 and 3 (each within the scatter of the next); then compound 4; then compound 1.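

In this assay, a long unbranched chain without a ring on the sulfur is accepted but does not match the ring-ended chain of compound 2 (a 3.0-fold higher number from compound 2 to compound 4 (0.48 log units; beyond the scatter)). It still improves on the shorter ring-ended chain of compound 1 (a 4.2-fold lower number from compound 1 to compound 4 (0.62 log units; beyond the scatter)), which places compound 4 between the two. The large drop seen when the chain of compound 1 grew by one carbon therefore does not carry on as a simple rule that longer is better, with compound 4 as the compound that goes against it, and nothing shown here accounts for where this chain lands.

As far as these compounds go, what remains open is how the number moves with chain length between these points, since an unbranched hexyl chain or a 4-phenylbutyl group on the sulfur would show whether there is a best length and whether a terminal ring matters at that length. Also unresolved is how this position responds to a chain ending in an amine or a carboxylic acid, since every group shown on the sulfur consists of carbon and hydrogen only.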